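The compounds below may be only part of what the source reports. "The series", "measured", "known", "first", "only" and "open" are said of these compounds alone.

Measured in a functional assay on DU-145 cells (Homo sapiens) for cytotoxicity, read by ELISA, with a stated time of 2 days; on this read-out higher numbers stand for weaker inhibition and lower numbers for stronger inhibition:
Compound 1 `Oc1ccc(-c2cc(-c3ccccc3)cc(-c3ccc(O)cc3)n2)cc1`: 22000 nM
Compound 2 `Oc1cccc(-c2cc(-c3ccccc3)nc(-c3cccs3)c2)c1`: 19700 nM

Compound 2, at 19700 nM, lies within the usual scatter of compound 1, so this assay does not separate the two. Compound 3 `Oc1cccc(-c2cc(-c3ccccc3)nc(-c3cccnc3)c2)c1` has not yet been measured. It carries pyridin-3-yl in place of thiophen-2-yl on an aromatic carbon, next to the ring nitrogen (pyridin-3-yl in place of thiophen-2-yl on an aromatic carbon). Within the data shown here, no measured pair differs in one place alone, so the data give no direct guide to this exchange. Among the measured compounds shown here, the only anchors are compound 1, at 22000 nM, and compound 2, at 19700 nM. On that basis, no step beyond the scatter is expected in this assay, in either direction. The expected change is a 1.1-fold higher number from compound 2 to compound 3 (0.05 log units; within the scatter). For compound 3 the estimated value is 22000 nM, with an expected range from 9000 nM to 55000 nM.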

Compound 3, half-maximal inhibitory concentration: 18900 nM
For compound 3 the middle estimate is 1.2-fold (0.07 log units) above the measured one; the range from low to high includes it.
By their numbers in this assay, from the lowest: compounds 3, 2 and 1 (each within the scatter of the next).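

In this assay, the exchange of thiophen-2-yl for pyridin-3-yl on an aromatic carbon, next to the ring nitrogen, gives a 1.0-fold lower number from compound 2 to compound 3 (0.02 log units; within the scatter). This is the first pair shown that differs in one place alone, and it shows that this assay does not separate a five-membered aromatic ring carrying sulfur from a six-membered aromatic ring carrying nitrogen at this position, despite the change in ring size. No supporting measurement bears on this result, so no cause can be given for it. The compounds shown leave open whether a non-aromatic group at this position, such as an amine, a carboxylic acid or a longer alkyl chain, would give a step beyond the scatter. They also leave open whether the same exchange reads alike when the phenyl group gives way to another group.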